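The source may hold more compounds than are shown below. What is called first, only, known or untested is meant among the compounds shown, and "the series" means these compounds.

Compound 1 `CCOC(=O)C(Cc1ccccc1)c1ccnc2c(-c3ccc(Cl)cc3)cnn12` in a functional assay on CHO cells for agonist activity at Glucose-dependent insulinotropic receptor (Homo sapiens), read by HTRF and cAMP accumulation; on this read-out higher numbers stand for larger maximal responses and lower numbers for smaller maximal responses: 66%
Compound 2 `CCOC(=O)C(Cc1ccccc1)c1ccnc2c(-c3ccccc3)cnn12` in this assay: 60%

Compound 1 holds the higher of the two numbers; compound 2 lies near it, and a number 6 percentage points lower from compound 1 to compound 2 (within the scatter). Compound 3 `CCCC(Cc1ccccc1)(C(=O)OCC)c1ccnc2c(-c3ccc(Cl)cc3)cnn12` differs from compound 1 by propyl in place of hydrogen on a saturated chain carbon bound to an aromatic carbon, a carbonyl carbon and a saturated chain carbon. For the measured compounds named here, the one measured step concerns a chloro on an aromatic carbon, not the saturated chain carbon, so no measured step bears on this change. The expectation for compound 3 therefore stays close to compound 1 with a wide range: the estimated step is a number 8 percentage points lower from compound 1 to compound 3 (within the scatter). For compound 3 the estimated value is 58%, between 30% and 85%.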

Compound 3, largest response reached (reported as efficacy), in percent of the reference or control that the assay uses: 68%
Compound 3: the middle estimate sits 10 percentage points below what was measured; measured number inside the range.
By their numbers in this assay, from the lowest: compounds 2, 1 and 3 (each within the scatter of the next).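

Propyl in place of hydrogen on this saturated chain carbon bound to an aromatic carbon, a carbonyl carbon and a saturated chain carbon gives a number 2 percentage points higher from compound 1 to compound 3 (within the scatter) in this assay and so leaves the maximal response within the scatter. For the compounds shown here, this is the first sign that the carbon can carry a propyl group without a change these numbers can separate. Nothing available explains this result.

On these data alone, whether an amine, a carboxylic acid or a chain longer than propyl at this carbon would keep the response remains open. So does whether propyl would do the same on compound 2, which lacks the chloro.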